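Swapping methoxymethyl for formyl on a saturated chain

The source may report more compounds than this note shows. Statements on the series, on what has been measured and on what is new or still open speak of the compounds shown alone.

Measured in a functional assay on Hs-578T cells (Homo sapiens) for antiproliferative activity; on this read-out lower numbers stand for stronger inhibition of growth and higher numbers for weaker inhibition of growth
compound 1 `COCCCCCCCCCCCCCCC/C=C1/CC(CO)(COC(=O)C(C)(C)C)OC1=O` gives 6.77 ug/mL
compound 2 `COCCCCCCCCCCCCCCC/C=C1\CC(CO)(COC(=O)C(C)(C)C)OC1=O` gives 5.45 ug/mL
compound 3 `COC(=O)CCCCCCCCCCCCCC/C=C1\CC(CO)(COC(=O)C(C)(C)C)OC1=O` gives > 10 ug/mL, a limit

Going by the values given here, only one step in this small set joins two true numbers, a 1.2-fold lower number from compound 1 to compound 2 (0.09 log units; within the scatter), so compound 1 cannot be told apart from its partner. For compound 3, > 10 ug/mL is a limit of the assay and not a number.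

Compound 4 `CC(C)(C)C(=O)OCC1(CO)C/C(=C/CCCCCCCCCCCCCCC=O)C(=O)O1` has not yet been measured. Its difference from compound 1 is formyl in place of methoxymethyl on a saturated chain carbon, ten or more bonds along the chain from a double-bonded chain carbon, which means formyl in place of methoxymethyl on a saturated chain carbon, ten or more bonds along the chain from a double-bonded chain carbon.

The closest guide is a change at the same place, methoxycarbonyl in place of methoxymethyl, seen as an at least 1.8-fold higher number from compound 2 to compound 3 (0.26 log units; that floor lies within the scatter). Because an at least 1.8-fold higher number from compound 2 to compound 3 (0.26 log units; that floor lies within the scatter) gives only a floor, a small move toward weaker inhibition of growth is expected, and no more than that. The estimated change is a 1.3-fold higher number from compound 1 to compound 4 (0.10 log units; within the scatter). For compound 4 the expected value is 8.5 ug/mL, with an estimated range from 4 ug/mL to 16 ug/mL.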

Compound 4, concentration for 50% growth inhibition: > 10 ug/mL
Compound 4 gave a limit, no number; the forecaster's own chance of this, stated with the estimate: 40%; at least 1.1-fold (0.07 log units) between middle value and limit.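

In this assay compound 4 gives > 10 ug/mL, which is a limit of the assay and not a number. Read as a step, this is an at least 1.4-fold higher number from compound 1 to compound 4 (0.16 log units; that floor lies within the scatter), so formyl, like methoxycarbonyl before it, yields no measured number at this place, yet no loss beyond the scatter is shown. Two different replacements of methoxymethyl now end the same way, one made on compound 1 and one on compound 2, and the true size of either change stays hidden because both results stop at the same limit: the limit of > 10 ug/mL in this assay, at which 2 of the 4 values shown sit.

The compounds shown leave open whether the true values of compound 3 and compound 4 lie close to that limit or far from it. On these data alone, how an amine or a carboxylic acid in place of methoxymethyl on this saturated chain carbon would read also remains open.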